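This account rests on a few compounds, and the source may have more. Where it says the series, first, only, none or still open, it means among the compounds named here.

Measured compounds in an assay on CHO-K1 cells for displacement of a labelled ligand from adenosine receptor A1 (Homo sapiens), tested at 10 uM; a higher number here means more inhibition at the concentration tested (going by the name of the read-out), a lower number less inhibition:
compound 1 `Nc1scc(-c2cccc(C(F)(F)F)c2)c1C(=O)c1ccccc1` gives 61.1%
compound 2 `CC(=O)c1cccc(-c2sc(N)c(C(=O)c3ccccc3)c2-c2cccc(C(F)(F)F)c2)c1` gives 33.1%
compound 3 `CC(=O)c1ccc(-c2sc(N)c(C(=O)c3ccccc3)c2-c2cccc(C(F)(F)F)c2)cc1` gives 25.6%

Compound 1 stands highest of the three in this assay; its nearest neighbour is compound 2, a number a number 28 percentage points lower from compound 1 to compound 2 (beyond the scatter), and the furthest is compound 3, a number a number 35.5 percentage points lower from compound 1 to compound 3 (beyond the scatter).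

Compound 4 `Nc1sc(-c2ccc([N+](=O)[O-])cc2)c(-c2cccc(C(F)(F)F)c2)c1C(=O)c1ccccc1` has not yet been measured. It differs from compound 1 by one exchange: 4-nitrophenyl in place of hydrogen on an aromatic carbon. The two measured steps from compound 1 are of the same kind, a hydrogen on an aromatic carbon replaced by a substituted phenyl ring. Both lowered the inhibition clearly: a number 28 percentage points lower from compound 1 to compound 2 (beyond the scatter) and a number 35.5 percentage points lower from compound 1 to compound 3 (beyond the scatter). Between compound 2 and compound 3 the difference was a number 7.5 percentage points lower from compound 2 to compound 3 (within the scatter), so the position of the substituent on the added ring mattered little there. Compound 4 is therefore expected to show a drop of similar size, a number 31.1 percentage points lower from compound 1 to compound 4 (beyond the scatter). For compound 4 the estimated value is 30%, expected to lie between 14% and 48%.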

Compound 4, a percentage reported as inhibition, at one concentration (the size of the read-out at that concentration, not a potency): 34.8%
Compound 4: middle estimate off by 4.8 percentage points, on the low side; low and high end bracket the measured number.
By their numbers in this assay, from the lowest: compounds 3, 2 and 4 (each within the scatter of the next); then compound 1.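

In this assay, a 4-nitrophenyl group next to the ring sulfur also lowers the inhibition relative to the hydrogen of compound 1 (a number 26.3 percentage points lower from compound 1 to compound 4 (beyond the scatter)). The drop therefore also appears with a nitro group on the added ring, not only with an acetyl group. Compound 4 cannot be told apart from either acetyl compound (a number 9.2 percentage points higher from compound 3 to compound 4 (within the scatter); a number 1.7 percentage points higher from compound 2 to compound 4 (within the scatter)), so across these three compounds neither the exchange of acetyl for nitro nor the different placement in compound 2 gives a readable change, and nothing available explains the drop.

Going by these compounds, what a phenyl ring with no substituent would do at this position stays open, as does the effect of a ring carrying an amine or a carboxylic acid. Also open, on these data alone, is whether a small group such as methyl, in place of a ring, would lower the inhibition too.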